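Swapping the Naphthyl Group of a Cyanopyridine Inhibitor

The compounds below may be only part of what the source reports. "The series", "measured", "known", "first", "only" and "open" are said of these compounds alone.

Three close relatives of one core have been tested in a functional assay on aorta (strain Wistar) for inhibition, with Thoracic aorta (Rattus norvegicus) as the target; on this read-out lower numbers stand for stronger inhibition and higher numbers for weaker inhibition. Compound 1 `COc1nc(-c2cc3ccccc3o2)cc(-c2cccc3ccccc23)c1C#N` gives 359000 nM. Compound 2 `CCOc1nc(-c2cc3ccccc3o2)cc(-c2cccc3ccccc23)c1C#N` carries an ethoxy group where compound 1 carries a methoxy group; in this assay compound 2 gives 344000 nM. Compound 3 `COc1nc(-c2cc3ccccc3o2)cc(-c2ccc(Cl)cc2Cl)c1C#N` gives 322000 nM. Compound 2 therefore lies within the scatter of compound 1 and within the scatter of compound 3, so none of the three can be told apart on this assay.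

For the measured compounds named here, the only measured step, a 1.0-fold lower number from compound 1 to compound 2 (0.02 log units; within the scatter), concerns the ethoxy group alone. Compound 4 `CCOc1nc(-c2cc3ccccc3o2)cc(-c2ccc(F)cc2)c1C#N` instead changes the aryl group: 4-fluorophenyl in place of naphthalen-1-yl on an aromatic carbon. Going by the values given here, no measured step touches this position, so nothing in the data speaks for a shift in either direction, and a number close to compound 2 is the plainest expectation. Compound 4 is thus expected to give about 340000 nM, between 150000 nM and 750000 nM. The step from compound 2 is estimated as a 1.0-fold lower number from compound 2 to compound 4 (0.01 log units; within the scatter), within the scatter.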

Compound 4, half-maximal inhibitory concentration: 396000 nM
The estimate for compound 4 lay 1.2-fold (0.07 log units) below the measured number; measured number inside the range.
By their numbers in this assay, from the lowest: compounds 3, 2, 1 and 4 (each within the scatter of the next).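

The step at the aromatic carbon opposite the ring nitrogen, with 4-fluorophenyl in place of naphthalen-1-yl, gives in this assay a 1.2-fold higher number from compound 2 to compound 4 (0.06 log units; within the scatter), the first listed step at this position. One six-membered aromatic ring of carbon only, carrying a fluorine, thus stands in for two such rings, and this read-out cannot tell compound 2 and compound 4 apart. Nothing measured here bears on why the read-out stays within the scatter across this change.

The compounds shown leave open whether a saturated ring such as cyclohexyl at this position would move the number beyond the scatter. They also leave open whether an amine or a carboxylic acid in place of the ethoxy group would do so.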